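The source may hold more compounds than are shown below. What is called first, only, known or untested is meant among the compounds shown, and "the series" means these compounds.

Values measured in a physicochemical assay for lipophilicity, at pH 7.4; a lower number here means a more polar compound, a higher number a more lipophilic compound:
- compound 1 `Cc1cc(NC(=O)C2CCCC2)nn1Cc1cc(Cl)ccc1OCc1ccccc1`: 3.5
- compound 2 `Cc1cc(NC(=O)C2CCCC2)nn1Cc1cc(Cl)ccc1OCC(C)C`: > 3.7 (a limit, not a number)

Compound 2 stands at the limit of > 3.7 in this assay, at which 1 of the 2 values shown sits. This is a limit of the assay, not a number.

Compound 3 `Cc1cc(NC(=O)OC(C)(C)C(F)(F)F)nn1Cc1cc(Cl)ccc1OCC(C)C` keeps the rest of compound 2 and changes one group, with 1-methyl-1-(trifluoromethyl)ethoxy in place of cyclopentyl on a carbonyl carbon.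

Among the compounds with values here, only one measured step is available, a number at least 0.20 log units higher from compound 1 to compound 2 (that floor lies within the scatter). Within the data shown here, it lies at a different place in the molecule, so it offers only a loose guide to size, and no measured step touches this carbonyl group. A modest upward step is therefore expected in this assay, with wide uncertainty. The expected step is a step that the limit leaves unreadable from compound 2 to compound 3. The estimate for compound 3 is 4, with an expected range from 3.5 to 4.6.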

Compound 3, distribution coefficient: 3.5
Estimate against measurement, compound 3: 0.50 log units above; the measured number falls inside the stated range.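

Compounds 1 and 2 both carry cyclopentyl on the carbonyl carbon, so this pair alone speaks to that position. In this assay, placing 1-methyl-1-(trifluoromethyl)ethoxy there gives a number at least 0.20 log units lower from compound 2 to compound 3 (that floor lies within the scatter), so the direction is downward even though the entering group has no ring and brings oxygen and fluorine. Compound 2 has a limit, not a number, so the full size of this step cannot be read: the limit of > 3.7 in this assay, at which 1 of the 3 values shown sits.

The swap removes a ring and adds oxygen and fluorine in one move, and the compounds shown do not separate these parts. A tert-butoxy group on the same carbonyl carbon, which keeps the oxygen and the branching but carries no fluorine, would show how much of the step goes with the trifluoromethyl group.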